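The source may report more compounds than this note shows. Statements on the series, on what has been measured and on what is new or still open speak of the compounds shown alone.

Within the data shown here, in an ADME assay (liver) for metabolic stability, with Liver microsome (Homo sapiens) as the target, read by LC-MS, using microsomes and NADPH, with a stated time of 5 min, at 37 degrees C (a higher number here means faster removal of the compound, a lower number slower removal), compound 2 `CCn1c([C@@H](C)NS(=O)(=O)c2ccccc2)nc2ccc(C(F)(F)F)cc21` gives 14 mL.min-1.g-1, the only true number so far. Compound 1 `CCn1c([C@@H](C)NS(=O)(=O)c2ccc(Cl)cc2)nc2ccc(C(F)(F)F)cc21` gives > 100 mL.min-1.g-1, which is a limit of the assay. Compound 3 `CCn1c([C@@H](C)NS(=O)(=O)c2ccc(F)cc2)nc2ccc(C(F)(F)F)cc21` follows from compound 2 by fluoro in place of hydrogen on an aromatic carbon, with fluoro in place of hydrogen on an aromatic carbon. Among the measured compounds shown here, the one measured step that bears on this is an at least 7.1-fold lower number from compound 1 to compound 2 (0.85 log units; beyond the scatter), where chloro gives way to hydrogen. A smaller move in the opposite direction is therefore expected, possibly staying within the scatter. The expected step is a 1.6-fold higher number from compound 2 to compound 3 (0.20 log units; within the scatter). For compound 3 the estimate is 22 mL.min-1.g-1, with an expected range of 9 mL.min-1.g-1 to 60 mL.min-1.g-1.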

Compound 3, intrinsic clearance in microsomes: 26 mL.min-1.g-1
The estimate for compound 3 lay 1.2-fold (0.07 log units) below the measured number; the measured number falls inside the stated range.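

In this assay, fluoro on this aromatic carbon cannot be told apart from hydrogen: a 1.9-fold higher number from compound 2 to compound 3 (0.27 log units; within the scatter). Fluoro and chloro at the same place do separate, with an at least 3.8-fold lower number from compound 1 to compound 3 (0.58 log units; beyond the scatter), so the outcome here depends on which halogen is present and not merely on a halogen being there. Compound 1 is a limit of the assay, so that step has no upper end: the limit of > 100 mL.min-1.g-1 in this assay, at which 1 of the 3 values shown sits.

Open, as far as these compounds go, is whether a methoxy group or a nitrile at this place would stay with compound 2 and compound 3 or move toward compound 1. Also open, from the compounds shown here alone, is how fluoro would read elsewhere on this ring.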